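Compound 3 to compound 4: methyl to 2-hydroxyethyl

This account rests on a few compounds, and the source may have more. Where it says the series, first, only, none or still open, it means among the compounds named here.

In a functional assay, read by spectrophotometry (on this read-out lower numbers stand for an effect already at smaller amounts and higher numbers for an effect only at larger amounts of compound), compound 1 (`COc1ccc(-c2cc(=O)c3ccc(OCCCCCN4CCC(C)CC4)cc3o2)cc1`) gives 31.7 nM and compound 2 (`COc1ccc(-c2cc(=O)c3ccc(OCCCCCN4CCC(CCO)CC4)cc3o2)cc1`) gives 27.9 nM. Compound 3 (`COc1ccc(-c2cc(=O)c3ccc(OCCCCCCCN4CCC(C)CC4)cc3o2)cc1`) gives 42.6 nM, within the scatter of both others: a 1.3-fold higher number from compound 1 to compound 3 (0.13 log units; within the scatter) and a 1.5-fold higher number from compound 2 to compound 3 (0.18 log units; within the scatter).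

Compound 4 (`COc1ccc(-c2cc(=O)c3ccc(OCCCCCCCN4CCC(CCO)CC4)cc3o2)cc1`) differs from compound 3 by hydroxymethyl in place of hydrogen on a saturated chain carbon bound to a saturated ring carbon. For the measured compounds named here, the one measured precedent for this change is compound 2, with a 1.1-fold lower number from compound 1 to compound 2 (0.06 log units; within the scatter), which is within the scatter. No step beyond the scatter is therefore expected in this assay. The expected step is a 1.2-fold lower number from compound 3 to compound 4 (0.06 log units; within the scatter). The estimated value for compound 4 is 37 nM, with an expected range of 20 nM to 68 nM.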

Compound 4, half-maximal effective concentration: 35.7 nM
Compound 4: the middle estimate sits 1.0-fold (0.02 log units) above what was measured; the range from low to high includes it.
By their numbers in this assay, from the lowest: compounds 2, 1, 4 and 3 (each within the scatter of the next).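

In this assay, 4-(2-hydroxyethyl)piperidin-1-yl in place of 4-methylpiperidin-1-yl now also stands on the chain of compound 3, with a 1.2-fold lower number from compound 3 to compound 4 (0.08 log units; within the scatter), so the change reads alike on both chain lengths: the same change on two cores in this assay, a 1.1-fold lower number (0.06 log units; within the scatter) from compound 1 to compound 2 and a 1.2-fold lower number (0.08 log units; within the scatter) from compound 3 to compound 4, 1.1-fold (0.02 log units) apart, within the scatter of two such steps. The two hydroxyl-bearing compounds also stay level across chain lengths, with a 1.3-fold higher number from compound 2 to compound 4 (0.11 log units; within the scatter), and the two differences together give a 1.1-fold higher number from compound 1 to compound 4 (0.05 log units; within the scatter).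

No step shown yet lies beyond the scatter, so neither this position nor the chain length has been seen to move the number. Open, on these data alone, is whether a carboxylic acid or a primary amine in place of the terminal hydroxyl would do so.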